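Replacing 4-methylpiperazin-1-yl in Compound 1

The source may hold more compounds than are shown below. What is called first, only, known or untested is meant among the compounds shown, and "the series" means these compounds.

Within the data shown here, in a functional assay on HCC827 cells (Homo sapiens) for antiproliferative activity, read by MTT assay, with a stated time of 72 h (on this read-out lower numbers stand for stronger inhibition and higher numbers for weaker inhibition), compound 1 (`CN1CCN(c2ccc(Nc3ncc4nc(Sc5ccccc5)n(C5CCOCC5)c4n3)cc2)CC1`) gives 42.6 nM, the lowest number of the three measured so far. Compound 2 (`CC(C)n1c(Sc2ccccc2)nc2cnc(Nc3ccc(N4CCN(C)CC4)cc3)nc21`) reads 290 nM. Its isopropyl in place of oxan-4-yl on an aromatic nitrogen makes a modest step, a 6.8-fold higher number from compound 1 to compound 2 (0.83 log units; beyond the scatter). Compound 3 (`CN1CCN(c2ccc(Nc3ncc4nc(SCc5cccnc5)n(C5CCOCC5)c4n3)cc2)CC1`) reads 500 nM. Its (pyridin-3-yl)methyl in place of phenyl on a sulfur makes a large step, a 12-fold higher number from compound 1 to compound 3 (1.07 log units; beyond the scatter).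

Compound 4 (`CN(C)CCN(C)c1ccc(Nc2ncc3nc(Sc4ccccc4)n(C4CCOCC4)c3n2)cc1`) has not yet been measured. It carries (2-(dimethylamino)ethyl)(methyl)amino in place of 4-methylpiperazin-1-yl on an aromatic carbon, para to a large group: (2-(dimethylamino)ethyl)(methyl)amino in place of 4-methylpiperazin-1-yl on an aromatic carbon. It keeps the oxan-4-yl and the phenyl on sulfur of compound 1, the two places where the measured changes occurred. Among the measured compounds shown here, compound 2 and compound 3 both retain 4-methylpiperazin-1-yl, so no measured step shows what a change at this aromatic carbon does. The sizes of those two steps therefore cannot be carried over, and they serve only as a loose guide to the uncertainty. With the counted features of the two groups so closely matched, only a small upward drift is expected, with no clear step beyond the scatter. The estimated change is a 1.4-fold higher number from compound 1 to compound 4 (0.15 log units; within the scatter). For compound 4 the expected value is 60 nM, with an estimated range from 20 nM to 190 nM.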

Compound 4, half-maximal inhibitory concentration: 499 nM
Beside the measured number, compound 4's estimate is 8.3-fold (0.92 log units) below it; the whole stated range lies below it.
By their numbers in this assay, from the lowest: compound 1; then compounds 2, 4 and 3 (each within the scatter of the next).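

Opening the ring of 4-methylpiperazin-1-yl to give (2-(dimethylamino)ethyl)(methyl)amino, on an aromatic carbon para to a large group, is far from a silent exchange in this assay: it produces a 12-fold higher number from compound 1 to compound 4 (1.07 log units; beyond the scatter) even though the two groups have the same heavy atoms, hydrogen-bond donors and acceptors and no net charge, so the ring is the only counted feature that separates them. Among these compounds, the earlier compounds varied only the group on the aromatic nitrogen and the group on sulfur, so this is the first sign that the number also responds to a change at this aromatic carbon. Nothing measured here explains why the ring-opened group gives the weaker inhibition.

The compounds shown leave open whether a different ring at this place, such as morpholin-4-yl or piperidin-1-yl, or a shorter chain such as dimethylamino, would stay close to compound 1. They also leave open whether the same exchange would have a step of similar size with isopropyl on the aromatic nitrogen or with (pyridin-3-yl)methyl on the sulfur.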